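The source may report more compounds than this note shows. Statements on the series, on what has been measured and on what is new or still open speak of the compounds shown alone.

Compound 1 `COc1cc(-c2cc(/C=C/C(=O)c3ccc(N)cc3)[nH]n2)cc(OC)c1OC` gives in a functional assay on TK-10 cells (Homo sapiens) for cytotoxicity, read by sulforhodamine B assay, with a stated time of 48 h, tested at 1 uM (a lower number here means a stronger effect, a higher number a weaker effect of the compound at the concentration tested), a value of 102%.
Compound 2 `COc1ccc(C(=O)/C=C/c2cc(-c3cc(OC)c(OC)c(OC)c3)n[nH]2)cc1OC` gives in this assay a value of 71%.

Among the measured compounds shown here, compound 2 stands as the lower of the two numbers measured so far; the nearest number is that of compound 1, and the step of a number 31 percentage points lower from compound 1 to compound 2 (beyond the scatter) separates them. Compound 3 `COc1ccc(C(=O)/C=C/c2cc(-c3cc(OC)c(OC)c(OC)c3)n[nH]2)cc1` is the next member of this series. It differs from compound 2 by hydrogen in place of methoxy on an aromatic carbon, so the group on the carbonyl carbon goes from 3,4-dimethoxyphenyl to 4-methoxyphenyl. For the measured compounds named here, no measured step changes a methoxy in this way, so nothing measured bears on it directly; the only known step, a number 31 percentage points lower from compound 1 to compound 2 (beyond the scatter), shows that the group on the carbonyl carbon can move the number a great deal, but that step swaps a whole group rather than removing one methoxy. A small shift toward a weaker effect is expected, within the scatter, as the step of a number 9 percentage points higher from compound 2 to compound 3 (within the scatter). Compound 3 is therefore estimated at 80%, within a range from 60% to 100%.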

Compound 3, a percentage reported as activity, at one concentration (the size of the read-out at that concentration, not a potency): 92%
For compound 3 the middle estimate is 12 percentage points below the measured one; the measured number falls inside the stated range.
By their numbers in this assay, from the lowest: compound 2; then compounds 3 and 1 (each within the scatter of the next).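

In this assay the single methoxy that sits ortho to a methoxy group carries real weight: replacing it with hydrogen, which turns 3,4-dimethoxyphenyl into 4-methoxyphenyl, gives a number 21 percentage points higher from compound 2 to compound 3 (beyond the scatter). Much of what the earlier whole-group swap showed can therefore be tied to this one position. With that methoxy gone, the difference from the amino compound no longer stands out, as a number 10 percentage points lower from compound 1 to compound 3 (within the scatter), and no measurement on hand explains why this methoxy matters.

As far as these compounds go, whether a hydroxyl group, a fluorine atom or a longer ethoxy chain at this place would keep the number of compound 2 remains open. So does the outcome when the other methoxy is the one replaced with hydrogen.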